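The source may report more compounds than this note shows. Statements on the series, on what has been measured and on what is new or still open speak of the compounds shown alone.

Measured so far in a functional assay on NCI-H460 cells (Homo sapiens) for cytotoxicity, read by MTT assay, with a stated time of 3 days; a higher number here means a weaker inhibitor, a lower number a stronger inhibitor:
- compound 1 `N#Cc1c(NN)nc(SCc2nc3ccccc3[nH]2)nc1-c1ccccc1`: 2.6 nM
- compound 2 `CCNc1nc(SCc2nc3ccccc3[nH]2)nc(-c2ccccc2)c1C#N`: 2.87 nM

In this assay, within the data shown here, compound 2, at 2.87 nM, cannot be told apart from the only other measured compound, as the single available step shows: a 1.1-fold higher number from compound 1 to compound 2 (0.04 log units; within the scatter). The next compound, compound 3 `N#Cc1c(NC(N)=O)nc(SCc2nc3ccccc3[nH]2)nc1-c1ccccc1`, keeps the shared core and carries a new group: carbamoyl in place of ethyl on a nitrogen on an aromatic ring. In words, carbamoyl stands in place of ethyl on a nitrogen on an aromatic ring. Among the measured compounds shown here, that one step is the only measured evidence, since it also changes the group at this place. For the measured compounds named here, no measured compound carries carbamoyl, so the guide is thin. Resting on the small size of a 1.1-fold higher number from compound 1 to compound 2 (0.04 log units; within the scatter), no change beyond the scatter is expected in this assay. The expected step is a 1.0-fold higher number from compound 2 to compound 3 (0.02 log units; within the scatter). For compound 3 the estimate is 3 nM, with an expected range from 1 nM to 10 nM.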

Compound 3, half-maximal inhibitory concentration: 14.7 nM
Compound 3: the middle estimate sits 4.9-fold (0.69 log units) below what was measured; measured number above the stated range.
By their numbers in this assay, from the lowest: compounds 1 and 2 (each within the scatter of the next); then compound 3.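

In this assay, compound 1 and compound 2 had left this nitrogen looking tolerant of change, but carbamoyl does not behave like the two smaller groups: the move from ethylamino to ureido gives a 5.1-fold higher number from compound 2 to compound 3 (0.71 log units; beyond the scatter), and carbamoyl in place of amino gives a 5.7-fold higher number from compound 1 to compound 3 (0.75 log units; beyond the scatter). Both steps are modest but lie beyond the scatter, so the number here does depend on the group on this nitrogen. No measurement shown explains the shift.

The compounds shown leave open whether the higher number goes with the carbonyl itself, which an acetyl group on this nitrogen would test, or with the added nitrogen of the ureido group. They also leave open whether a longer chain, such as butyl, would stay level with ethyl.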